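Two Methoxy Groups Take the Place of a Fluorine

A few compounds are considered here, and "the series" means these few. Any claim that something is new, unique, unknown or untested is made for them only; others in the source may bear on it.

Compound 1 `COc1cccc(N2CCN(C(=O)c3oc(C)nc3-c3ccccc3)CC2)c1` sets the strongest mark of the two measured compounds: in a functional assay on HL-60 cells (Homo sapiens) for inhibition, read by MTT assay, with a stated time of 72 h (on this read-out higher numbers stand for weaker inhibition and lower numbers for stronger inhibition), compound 1 gives 34.8 nM. Compound 2 `Cc1nc(-c2ccccc2)c(C(=O)N2CCN(c3ccc(F)cc3)CC2)o1` carries 4-fluorophenyl in place of 3-methoxyphenyl on an amine nitrogen in a ring. For compound 2 this assay reports only a limit, > 1000 nM, and no exact number. The change from compound 1 to compound 2 therefore appears as an at least 28-fold higher number from compound 1 to compound 2 (1.45 log units; beyond the scatter), a loss whose size rests on (the limit of > 1000 nM in this assay, at which 1 of the 2 values shown sits). Compound 3 `COc1cc(OC)cc(N2CCN(C(=O)c3oc(C)nc3-c3ccccc3)CC2)c1` has not yet been measured; it differs from compound 2 by 3,5-dimethoxyphenyl in place of 4-fluorophenyl on an amine nitrogen in a ring. Within the data shown here, only the step from compound 1 to compound 2 bears on this, and it was large. Because compound 1 gives 34.8 nM and the incoming 3,5-dimethoxyphenyl resembles its 3-methoxyphenyl, compound 3 is expected to move back toward stronger inhibition, a step of an at least 16-fold lower number from compound 2 to compound 3 (1.22 log units; beyond the scatter). The estimate for compound 3 is 60 nM, with a likely range from 15 nM to 400 nM.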

Compound 3, half-maximal inhibitory concentration: 19.2 nM
Estimate against measurement, compound 3: 3.1-fold (0.49 log units) above, and the stated range covers the measured number.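

The swap from 4-fluorophenyl to 3,5-dimethoxyphenyl on the ring nitrogen, read in this assay, gives an at least 52-fold lower number from compound 2 to compound 3 (1.71 log units; beyond the scatter), so strong inhibition returns with a methoxy-bearing ring at this position. Adding a second methoxy to the ring of compound 1 gives a 1.8-fold lower number from compound 1 to compound 3 (0.26 log units; within the scatter), so the extra group brings no change that can be told apart from the scatter. Compound 2 is reported only as a limit, so the size of its step is a minimum and its true value is unknown: the limit of > 1000 nM in this assay, at which 1 of the 3 values shown sits.

The compounds shown leave open whether the weak result of compound 2 comes from the fluorine itself or from the missing methoxy, a question that plain phenyl would help to separate. Going by these compounds, it also remains open whether ethoxy, hydroxyl or an amine could stand in for methoxy and keep the inhibition.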